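The compounds below may be only part of what the source reports. "The series", "measured", "known", "first", "only" and "open" are said of these compounds alone.

Measured compounds in the series:

compound 1, `CC(C)(C)c1cc(C(C)(C)C)c2oc(=O)c(/C=N/c3ccc(S(N)(=O)=O)cc3)c(Cl)c2c1`; in a functional assay on B16-F10 cells (Mus musculus) for cytotoxicity, read by CCK-8 assay, with a stated time of 48 h (on this read-out higher numbers stand for weaker inhibition and lower numbers for stronger inhibition), compound 1 gives 240 nM
compound 2, `CC(C)(C)c1cc(C(C)(C)C)c2oc(=O)c(/C=N/c3ccc(S(=O)(=O)NC(=N)N)cc3)c(Cl)c2c1`; in this assay compound 2 gives 250 nM
compound 3, `Cc1cc(C)nc(NS(=O)(=O)c2ccc(/N=C/c3c(Cl)c4cc(C(C)(C)C)cc(C(C)(C)C)c4oc3=O)cc2)n1`; in this assay compound 3 gives 220 nM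

The three numbers sit close together. Compound 3 has the lowest of them, but the gaps to the other two are small: a 1.1-fold lower number from compound 1 to compound 3 (0.04 log units; within the scatter) and a 1.1-fold lower number from compound 2 to compound 3 (0.06 log units; within the scatter). Likewise a 1.0-fold higher number from compound 1 to compound 2 (0.02 log units; within the scatter). All three compounds share the same core and differ only in what sits on the sulfonamide nitrogen, and none of the three steps there has moved the number beyond the scatter.

The unmeasured compound 4, `Cc1cc(NS(=O)(=O)c2ccc(/N=C/c3c(Cl)c4cc(C(C)(C)C)cc(C(C)(C)C)c4oc3=O)cc2)no1`, continues the same theme: 5-methyl-1,2-oxazol-3-yl in place of 4,6-dimethylpyrimidin-2-yl on a sulfonamide nitrogen. The bearing steps are therefore those already made on that nitrogen, from hydrogen to a three-atom group, from hydrogen to the dimethylpyrimidinyl, and between those two, each within the scatter. Within the data shown here, nothing among the measured compounds suggests that a further exchange of the substituent on this nitrogen should do more. The expectation in this assay is accordingly a step of a 1.0-fold higher number from compound 3 to compound 4 (0.02 log units; within the scatter), that is, no change beyond the scatter. Compound 4 is expected to give 230 nM, with a likely range from 120 nM to 460 nM.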

Compound 4, half-maximal inhibitory concentration: 240 nM
Beside the measured number, compound 4's estimate is 1.0-fold (0.02 log units) below it; the range from low to high includes it.
By their numbers in this assay, from the lowest: compounds 3, 1, 4 and 2 (each within the scatter of the next).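

In this assay, 5-methyl-1,2-oxazol-3-yl on the sulfonamide nitrogen reads like 4,6-dimethylpyrimidin-2-yl, with a 1.1-fold higher number from compound 3 to compound 4 (0.04 log units; within the scatter) for the exchange of a six-membered aromatic ring for a five-membered one, which also brings one nitrogen and one oxygen in place of two nitrogen as hetero atoms. The same holds against the open-chain group of compound 2, with a 1.0-fold lower number from compound 2 to compound 4 (0.02 log units; within the scatter) as the step, and against the unsubstituted sulfonamide of compound 1, with no change at the digits printed from compound 1 to compound 4 (within the scatter) as the step. This nitrogen has now carried hydrogen, a group with no ring and two different aromatic rings, and across these four compounds a second ring type joins the first in leaving the number within the scatter, so ring size and hetero atom identity show no effect here in this assay.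

From the compounds shown here alone, whether a carboxylic acid or a longer alkyl chain on this nitrogen would give a step beyond the scatter remains open, as does the effect of an amine in place of the chlorine on the shared core. No supporting data explain why the numbers stay together across these substituents.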